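Working notes: cytotoxicity across the shared core, toward compound 4

This account rests on a few compounds, and the source may have more. Where it says the series, first, only, none or still open, it means among the compounds named here.

Measured to date in an ADME assay on HEK-293T cells (Homo sapiens) for cytotoxicity, read by CCK-8 assay, with a stated time of 24 h; a higher number here means that more compound is tolerated, a lower number that less compound is tolerated:
- compound 1, `C[C@@H](NC(=O)CSc1c[nH]c2ccccc12)c1ccccc1`: compound 1 gives > 100000 nM, a limit of the assay.
- compound 2, `CN(Cc1ccccc1)C(=O)CSc1c[nH]c2ccccc12`: compound 2 gives > 100000 nM, likewise a limit.
- compound 3, `Cn1cc(SCC(=O)NCc2ccccc2)c2ccccc21`: compound 3 gives 95500 nM.

For the measured compounds named here, compound 3 stands as the only actual number among the values shown; the other two sit at the limit of > 100000 nM in this assay, at which 2 of the 3 values shown sit. Nothing separates compound 3 from them beyond the scatter.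

Compound 4, `O=C(CSc1c[nH]c2ccccc12)NCc1ccccc1`, is next, with the change (hydrogen in place of methyl on an aromatic nitrogen). Going by the values given here, no measured pair shows this change, so no step is counted. In this assay an expected step of a 1.0-fold higher number from compound 3 to compound 4 (0.02 log units; within the scatter) from compound 3 is none beyond the scatter. Compound 4 is estimated at 100000 nM, range 50000 nM to 200000 nM, pending measurement.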

Compound 4, half-maximal cytotoxic concentration: > 100000 nM
Compound 4 gave a limit, no number (the forecaster's own chance of this, stated with the estimate: 60%); the middle value lies on the limit itself.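

Hydrogen in place of methyl on an aromatic nitrogen now has its first counted step in this assay: an at least 1.0-fold higher number from compound 3 to compound 4 (0.01 log units; that floor lies within the scatter). From the compounds shown here alone, that step is only a floor, so the change shows no effect beyond the scatter, and its true size stays unknown. The steps to compound 4 from compound 1 and compound 2 cannot be read because both ends of each are limits: the limit of > 100000 nM in this assay, at which 3 of the 4 values shown sit.

Going by these compounds, whether a longer chain or a carboxylic acid on this aromatic nitrogen would give a clearly lower number in this assay remains open. The upper end of tolerance for the series also remains unresolved.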